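Swapping carboxymethyl for acetyl on compound 3

This account rests on a few compounds, and the source may have more. Where it says the series, first, only, none or still open, it means among the compounds named here.

Measured in a functional assay on the whole organism for inhibition, with Rattus norvegicus as the target; on this read-out lower numbers stand for stronger inhibition and higher numbers for weaker inhibition:
Compound 1 `O=C1ON=C(c2cccs2)/C1=C/c1ccccc1`: 4400 nM
Compound 2 `O=C1ON=C(c2cccs2)/C1=C/c1ccc(Cl)cc1`: 6200 nM
Compound 3 `O=C(O)COc1ccc(/C=C2\C(=O)ON=C2c2cccs2)cc1`: 100000 nM

Compound 3 has the highest number of the three, which makes it the weakest inhibitor so far, and its gaps to both others lie beyond the scatter. Compound 4 `CC(=O)Oc1ccc(/C=C2\C(=O)ON=C2c2cccs2)cc1` is the next to be tested. It carries acetyl in place of carboxymethyl on an oxygen on an aromatic ring.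

Going by the values given here, two measured steps bear most directly on this change. Carboxymethoxy in place of hydrogen gave a 23-fold higher number from compound 1 to compound 3 (1.36 log units; beyond the scatter), and carboxymethoxy in place of chloro gave a 16-fold higher number from compound 2 to compound 3 (1.21 log units; beyond the scatter). Both are large. Chloro in place of hydrogen, by contrast, gave only a 1.4-fold higher number from compound 1 to compound 2 (0.15 log units; within the scatter), which is within the scatter. Only the compound with carboxymethoxy stands apart. Among the compounds with values here, compound 4 no longer has that group, although no compound with acetoxy has been measured, so the guess remains loose. A large step to a lower number is therefore expected in this assay, bringing compound 4 into the region of compound 1 at 4400 nM and compound 2 at 6200 nM. The estimated change is a 14-fold lower number from compound 3 to compound 4 (1.15 log units; beyond the scatter). For compound 4 the expected value is 7000 nM, with an estimated range from 2500 nM to 20000 nM.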

Compound 4, half-maximal inhibitory concentration: 4500 nM
Compound 4: middle estimate off by 1.6-fold (0.19 log units), on the high side; the range from low to high includes it.
By their numbers in this assay, from the lowest: compounds 1, 4 and 2 (each within the scatter of the next); then compound 3.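

In this assay, the swap of carboxymethyl for acetyl on an oxygen on an aromatic ring gives a 22-fold lower number from compound 3 to compound 4 (1.35 log units; beyond the scatter), so an oxygen-linked group at this place does not by itself go with a high number, and the large rise belongs to carboxymethoxy among the groups tested here. Acetoxy also matches the two simpler compounds, with a 1.4-fold lower number from compound 2 to compound 4 (0.14 log units; within the scatter) against chloro and a 1.0-fold higher number from compound 1 to compound 4 (0.01 log units; within the scatter) against hydrogen, so hydrogen, chloro and acetoxy cannot be told apart in this assay, while carboxymethoxy alone stands apart. No measurement shown here offers a reason for the gap between carboxymethyl and acetyl.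

The compounds shown leave open which part of carboxymethoxy goes with the high number, since a methyl ester of that group, a plain methoxy or a hydroxyl at the same place could fall with compound 1, compound 2 and compound 4 or with compound 3. They also leave open whether an amine, or a carboxylic acid on a longer chain, would give a number as high as that of compound 3.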